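The source may hold more compounds than are shown below. What is called first, only, known or untested is meant among the compounds shown, and "the series" means these compounds.

Compound 1 `CC(C)(C)c1ccc(C(=O)NN2C(=O)NC3(CC3(C)C)C2=O)cc1` gives 100 mg/kg in a functional assay on the whole organism (Hindlimb) for inhibition, with Mus musculus as the target, with a stated time of 4 h; on this read-out lower numbers stand for an effect already at smaller amounts and higher numbers for an effect only at larger amounts of compound.
Compound 2 `CC1(C)CC12NC(=O)N(NC(=O)c1ccc(Cl)cc1)C2=O` gives 300 mg/kg in this assay.
Compound 3 `CC1(C)CC12NC(=O)N(NC(=O)c1ccc([N+](=O)[O-])cc1)C2=O` gives 300 mg/kg in this assay.

Among the measured compounds shown here, compound 2 stands level with compound 3, the two together at the highest number of the three, and the move a 3.0-fold higher number from compound 1 to compound 2 (0.48 log units; beyond the scatter) marks compound 1 as the one with the lower number. The unmeasured compound 4 `CC1(C)CC12NC(=O)N(NC(=O)c1ccco1)C2=O` differs from compound 2 in one place: furan-2-yl in place of 4-chlorophenyl on a carbonyl carbon. For the measured compounds named here, no measured step exchanges one aromatic group for another of a different ring size, so the nearest guidance comes from changes on the same aromatic ring: a 3.0-fold higher number from compound 1 to compound 2 (0.48 log units; beyond the scatter) and a 3.0-fold higher number from compound 1 to compound 3 (0.48 log units; beyond the scatter) were modest, and no change at the digits printed from compound 2 to compound 3 (within the scatter) stayed within the scatter. Because the step of no change at the digits printed from compound 2 to compound 3 (within the scatter) shows that a further change on the aromatic group left the number where it was, the step of no change at the digits printed from compound 2 to compound 4 (within the scatter) is expected to be small or none beyond the scatter, with no direction favoured. Compound 4 is therefore estimated at 300 mg/kg, in a range from 100 mg/kg to 1000 mg/kg.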

Compound 4, minimum effective dose: 300 mg/kg
Estimate against measurement, compound 4: no gap at the digits printed; the measured number falls inside the stated range.
By their numbers in this assay, from the lowest: compound 1; then compounds 2, 3 and 4 (each within the scatter of the next).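

Earlier steps changed only the group on a phenyl ring, whereas here the whole ring is exchanged, and the outcome is no change at the digits printed from compound 2 to compound 4 (within the scatter) in this assay. On this carbonyl carbon, whose other neighbour is an amide-type nitrogen, the six-membered aromatic ring of carbon only can thus give way to the smaller five-membered aromatic ring with 1 hetero atom without the number moving beyond the scatter. Nothing measured in the material shown accounts for this result.

The compounds shown leave open whether an aromatic ring is needed here at all, as a cyclohexyl group or a longer alkyl chain on this carbonyl carbon might or might not keep the number. Also open, as far as these compounds go, is whether a tert-butyl group on the furan ring would bring the number towards that of compound 1, 100 mg/kg in this assay.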